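Single configured form of the chain stereocentre

This account rests on a few compounds, and the source may have more. Where it says the series, first, only, none or still open, it means among the compounds named here.

Measured compounds:
compound 1, `CCCN(Cc1cnc(Nc2ccc(C)nc2)c(Cl)c1)C(=O)c1nccs1`, 584 nM
compound 2, `CCCC(NC(=O)c1nccs1)c1cnc(Nc2ccc(C)nc2)c(Cl)c1`, 28.7 nM

In a functional assay on HEK293 cells for negative allosteric modulation of metabotropic glutamate receptor 5 (Homo sapiens), read by HTRF and inositol phosphate accumulation (on this read-out higher numbers stand for weaker inhibition and lower numbers for stronger inhibition), compound 2 gives 28.7 nM, the lowest of the two numbers shown; the only other number, that of compound 1 in this assay at 584 nM, lies higher by a gap beyond the scatter. Going by the values given here, compound 1 and compound 2 differ in more than one place, so no single step between them can be stated.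

Compound 3, `CCC[C@H](NC(=O)c1nccs1)c1cnc(Nc2ccc(C)nc2)c(Cl)c1`, differs from compound 2 as follows: the two compounds have the same atoms and bonds; at least one stereo element is drawn with a configuration in one of them and without one in the other: 1 of 1 stereo elements differ; a stereocentre at a saturated chain carbon is drawn without a configuration in compound 2 and S in compound 3. Among the compounds with values here, no step of this kind between measured compounds is available. A configured form of an unresolved centre may carry most of the activity or little of it, so the range is wide, and the central expectation for the step from compound 2 to compound 3 is a 1.1-fold lower number from compound 2 to compound 3 (0.06 log units; within the scatter), none beyond the scatter. Compound 3 is expected at 25 nM, with a range from 8 nM to 300 nM.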

Compound 3, half-maximal inhibitory concentration: 978 nM
The estimate for compound 3 lay 39-fold (1.59 log units) below the measured number; measured number above the stated range.
By their numbers in this assay, from the lowest: compound 2; then compounds 1 and 3 (each within the scatter of the next).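

In this assay, the saturated chain carbon proves sensitive to configuration, a point compounds 1 and 2 could not show: defining it as S gives a 34-fold higher number from compound 2 to compound 3 (1.53 log units; beyond the scatter), with atoms and bonds unchanged. The step can be traced to a single difference: the fact that one of compounds 2 and 3 is drawn with a defined configuration and the other without, at the place where they differ The S form therefore does not account for the low number of compound 2, at 28.7 nM, so that activity must reside elsewhere in the material drawn without a configuration.

Open, from the compounds shown here alone, is whether the R form at this carbon carries that activity, and what stereochemical composition underlies the number for compound 2. Also open, going by these compounds, is whether a longer chain or a cyclopropyl group at the same carbon would preserve this dependence on configuration.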